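Notes on the ethylamide and its hydroxyethyl analogue

The source may hold more compounds than are shown below. What is called first, only, known or untested is meant among the compounds shown, and "the series" means these compounds.

Compound 1 `CCNC(=O)CC1CCc2cc(OC)c(OC)cc21` is the ethylamide of the shared core. Within the data shown here, in a functional assay on the whole organism (strain Wistar) for inhibition, with Rattus norvegicus as the target, read by paw edema, with stated times of 60 min and 3 h, at a dose of 100 mg/kg by the oral route (on this read-out lower numbers stand for less inhibition and higher numbers for more inhibition at the one dose given (going by the name of the read-out)), compound 1 gives 26.1%, the higher of the two numbers measured so far. Compound 2 `COc1cc2c(cc1OC)C(CC(=O)NCc1ccccc1)CC2` carries phenyl in place of methyl on a saturated chain carbon bound to an amide-type nitrogen; in this assay compound 2 gives 14.5%, and the step of a number 11.6 percentage points lower from compound 1 to compound 2 (beyond the scatter) lies beyond the scatter. Compound 3 `COc1cc2c(cc1OC)C(CC(=O)NCCO)CC2` is not yet measured. It differs from compound 1 by hydroxy in place of hydrogen on a saturated chain carbon, two bonds along the chain from an amide-type nitrogen. Among the measured compounds shown here, no measured step bears directly on this change; the only step known, phenyl in place of methyl, is a different change and gives direction only loosely. The expectation for compound 3 in this assay is therefore a step of a number 1.1 percentage points lower from compound 1 to compound 3 (within the scatter) of no set direction, likely within the scatter. Compound 3 is estimated at 25%, within 10% to 42%.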

Compound 3, a percentage reported as inhibition, in the whole organism at one dose (the size of the read-out at that dose, not a potency): 12.3%
The estimate for compound 3 lay 12.7 percentage points above the measured number, and the stated range covers the measured number.
By their numbers in this assay, from the lowest: compounds 3 and 2 (each within the scatter of the next); then compound 1.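

In this assay, hydroxy in place of hydrogen on a saturated chain carbon, two bonds along the chain from an amide-type nitrogen, gives a number 13.8 percentage points lower from compound 1 to compound 3 (beyond the scatter) for a change of one heavy atom, so this position does respond to a small substitution. Hydroxymethyl in place of phenyl on the saturated chain carbon bound to an amide-type nitrogen gives a number 2.2 percentage points lower from compound 2 to compound 3 (within the scatter) and so separates neither group from the other. Of the three amides, the ethylamide alone stands apart, with both replacements lying lower and no compound shown going against this.

As far as these compounds go, whether a longer chain, a methoxyethyl group or a terminal amine or carboxylic acid would lie nearer to compound 1 stays open. So does whether the plain methylamide would lie above it. No measurement shown bears on why either replacement lowers the number.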